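The source may hold more compounds than are shown below. What is called first, only, known or untested is meant among the compounds shown, and "the series" means these compounds.

Working notes on the series. Compound 1 `O=C(Nc1ccccn1)c1cccc(Nc2ncc(F)c(Nc3ccc(F)cc3)n2)c1` and compound 2 `CN(C)c1ccc(C(=O)Nc2cccc(Nc3ncc(F)c(Nc4ccc(F)cc4)n3)c2)cc1` share one core and differ only in the group carried on the outer ring. Within the data shown here, in a functional assay on DU-145 cells (Homo sapiens) for antiproliferative activity, read by sulforhodamine B assay, with a stated time of 3 days (a higher number here means a weaker inhibitor of growth, a lower number a stronger inhibitor of growth), compound 1 gives 15100 nM, the only plain number so far. Compound 2 returns only a limit of the assay, > 10000 nM, and so sits at the limit of > 10000 nM in this assay, at which 1 of the 2 values shown sits. Among the measured compounds shown here, with a single number and a single limit, no measured step between compounds exists to set a scale for changes in this assay.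

Compound 3 `COCC(=O)Nc1cccc(Nc2ncc(F)c(Nc3ccc(F)cc3)n2)c1` is the next member, differing from compound 1 by ((methoxymethyl)carbonyl)amino in place of (pyridin-2-yl)carbamoyl on an aromatic carbon. For the measured compounds named here, as no step between measured compounds is in hand, the size of the change in this assay is open; the expectation is for no shift beyond the usual scatter, with a real chance that only a limit is returned. Compound 3 is expected at 13000 nM, between 4000 nM and 40000 nM. The step this estimate means is a 1.2-fold lower number from compound 1 to compound 3 (0.07 log units; within the scatter), expected to remain within the scatter.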

Compound 3, concentration for 50% growth inhibition: 4460 nM
The estimate for compound 3 lay 2.9-fold (0.46 log units) above the measured number, and the stated range covers the measured number.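

In this assay, this aromatic carbon gives its first readable step: ((methoxymethyl)carbonyl)amino in place of (pyridin-2-yl)carbamoyl gives a 3.4-fold lower number from compound 1 to compound 3 (0.53 log units; beyond the scatter), so the group here can move growth inhibition beyond the scatter. On the carbonyl carbon, methoxymethyl in place of 4-(dimethylamino)phenyl gives an at least 2.2-fold lower number from compound 2 to compound 3 (0.35 log units; beyond the scatter), so among these three compounds the group without a ring carries the lower number in both steps, with compound 1 and compound 2 offering no exception. Compound 2 gives only a limit, so that step has a floor and no exact size: the limit of > 10000 nM in this assay, at which 1 of the 3 values shown sits.

As far as these compounds go, whether the shift follows the loss of the aromatic ring or the presence of the ether oxygen remains open. An acetyl group, a longer alkoxyalkyl chain or a terminal amine on the same carbonyl would help separate the two.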